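Mirror-image pair: what a swapped stereocentre may do

A few compounds are considered here, and "the series" means these few. Any claim that something is new, unique, unknown or untested is made for them only; others in the source may bear on it.

The measured compounds, all sharing one brominated core, with their results in a functional assay on CCRF-CEM cells (Homo sapiens) for antiproliferative activity, read by MTT assay, with a stated time of 24 h, tested at 100 uM; on this read-out lower numbers stand for a stronger effect and higher numbers for a weaker effect at the one concentration tested:

compound 1 `COc1cccc(C(O)CCn2nc3c(Br)c(Br)c(Br)c(Br)c3n2)c1` — 48%
compound 2 `OC(CCn1nc2c(Br)c(Br)c(Br)c(Br)c2n1)c1cccc(Cl)c1` — 0%
compound 3 `C[C@@H](O)CCn1nc2c(Br)c(Br)c(Br)c(Br)c2n1` — 36%

In this assay compound 3 stands second highest of the three numbers. Its nearest neighbour is compound 1, which sits higher, and its furthest is compound 2, which sits far lower. Going by the values given here, the only step between two compounds that differ in one place is a number 48 percentage points lower from compound 1 to compound 2 (beyond the scatter), a change on the aromatic ring of the side chain.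

Compound 4 `C[C@H](O)CCn1nc2c(Br)c(Br)c(Br)c(Br)c2n1` has not yet been measured. Compared with compound 3: the two compounds have the same atoms and bonds and differ only in configuration as drawn: 1 of 1 stereo elements differ; a stereocentre at a saturated chain carbon is drawn R in compound 3 and S in compound 4

No measured step touches a change of configuration alone; the one step shown, a number 48 percentage points lower from compound 1 to compound 2 (beyond the scatter), replaces one group with another and therefore offers no guide here. Without such a comparison, the expectation for compound 4 is a step of no change at the digits printed from compound 3 to compound 4 (within the scatter), that is, no change beyond the scatter, though a real difference in either direction cannot be ruled out. Compound 4 is therefore estimated at 36%, with a range from 15% to 60%.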

Compound 4, a percentage reported as activity, at one concentration (the size of the read-out at that concentration, not a potency): 36%
Estimate against measurement, compound 4: no gap at the digits printed; the range from low to high includes it.
By their numbers in this assay, from the lowest: compound 2; then compounds 3 and 4 (each within the scatter of the next); then compound 1.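

In this assay, swapping the drawn configuration at the saturated chain carbon gives no change at the digits printed from compound 3 to compound 4 (within the scatter). At this one position and at the single concentration tested, therefore, the read-out does not separate the R form from the S form, which the earlier step could not show, as it replaced one group on an aromatic ring with another. Going by these compounds alone, this comparison isolates the stereocentre, and the reading can be tied to that centre alone because only one thing separates the pair: the fact that compounds 3 and 4 differ only in the configuration as drawn.

The compounds shown leave open whether the two forms would also match at lower concentrations, since a single-concentration read-out gives the size of an effect and not a potency. They also leave open whether configuration would matter with a different group on that carbon, such as the substituted phenyl rings of compound 1 and compound 2, whose stereocentre has no configuration drawn, or with an amine in place of the hydroxyl group, or with a longer chain linking that carbon to the shared core.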